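The source may hold more compounds than are shown below. What is called first, only, known or untested is meant among the compounds shown, and "the series" means these compounds.

Measured compounds:
compound 1 `CN1C/C(=C\c2ccc(F)cc2)C(=O)[C@]2(C1)[C@@H](c1ccc(F)cc1)CN(C)[C@@]21C(=O)N(C)c2ccccc21` — 75.8%
compound 2 `Cc1ccc(/C=C2\CN(C)C[C@@]3(C2=O)[C@@H](c2ccc(C)cc2)CN(C)[C@@]32C(=O)Nc3ccccc32)cc1` — 69.2%

In a functional assay on the whole organism (strain Wister albino) for inhibition, with Rattus norvegicus as the target, read by paw edema, with a stated time of 1 h, at a dose of 50 mg/kg by the intraperitoneal route (a lower number here means less inhibition, a higher number more inhibition at the dose given (going by the name of the read-out)), compound 1 gives 75.8% and compound 2 gives 69.2%. Compound 2 stands lowest of the two numbers, but its gap to compound 1 lies within the scatter, so no order between the two is claimed. Compound 3 `Cc1ccc(/C=C2\CN(C)C[C@@]3(C2=O)[C@@H](c2ccc(C)cc2)CN(C)[C@@]32C(=O)N(C)c3ccccc32)cc1` is not yet measured. It differs from compound 2 by methyl in place of hydrogen on an amide-type nitrogen in a ring. Among the compounds with values here, no step between measured compounds that differ in one place is known, so the step expected in this assay is small and not beyond the scatter, either way: a number 1.8 percentage points higher from compound 2 to compound 3 (within the scatter) is the estimated step. For compound 3 the expected value is 71%, with a range from 59% to 83%.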

Compound 3, a percentage reported as inhibition, in the whole organism at one dose (the size of the read-out at that dose, not a potency): 53.5%
Estimate against measurement, compound 3: 17.5 percentage points above; the measured number lies below the stated range.
By their numbers in this assay, from the lowest: compound 3; then compounds 2 and 1 (each within the scatter of the next).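

In this assay, within the data shown here, the amide-type nitrogen in a ring proves to be a position that responds: methyl in place of hydrogen there gives a number 15.7 percentage points lower from compound 2 to compound 3 (beyond the scatter) and is the first step that can be read at one place. This rests on a single pair and holds only for the shared core of compound 2 and compound 3. Nothing at hand bears on why the number falls at this position.

As far as these compounds go, whether ethyl or a longer chain on this nitrogen follows methyl remains open. Also open, from the compounds shown here alone, is whether the amide hydrogen would give a similar step on the core of compound 1.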